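Sulfonamide pairs at the limit; an amide replaces one side

The compounds below may be only part of what the source reports. "The series", "measured", "known", "first", "only" and "open" are said of these compounds alone.

Measured compounds in an assay on isolated protein for inhibition of thiosulfate sulfurtransferase (Homo sapiens); on this read-out lower numbers stand for stronger inhibition and higher numbers for weaker inhibition:
compound 1 `COc1ccc(S(=O)(=O)Nc2ccc(-c3nc4cc(NS(=O)(=O)c5ccc(OC)cc5)ccc4o3)cc2)cc1`: > 100000 nM, a limit of the assay.
compound 2 `O=S(=O)(Nc1ccc(-c2nc3cc(NS(=O)(=O)c4cccc5ccccc45)ccc3o2)cc1)c1cccc2ccccc12`: > 100000 nM, a limit of the assay.
compound 3 `Nc1ccc(S(=O)(=O)Nc2ccc(-c3nc4cc(NS(=O)(=O)c5ccc(N)cc5)ccc4o3)cc2)cc1`: > 100000 nM, a limit of the assay.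

All three measured compounds share one core and carry two sulfonamide arms of the same kind, one on each end. None of them gives a number in this assay: compound 1 sits at the limit, and so do compound 2 and compound 3 (the limit of > 100000 nM in this assay, at which 3 of the 3 values shown sit). Compound 1 therefore stands at the same place as the other two, with nothing to rank it above or below them.

Compound 4 `COc1ccc(S(=O)(=O)Nc2ccc3oc(-c4ccc(NC(=O)C5CCN(C(C)=O)CC5)cc4)nc3c2)cc1` keeps the methoxyphenyl sulfonamide on one end of the core but changes the other end: (1-acetylpiperidin-4-yl)carbonyl in place of (4-methoxyphenyl)sulfonyl on a nitrogen on an aromatic ring. In words, a (1-acetylpiperidin-4-yl)carbonyl replaces a (4-methoxyphenyl)sulfonyl on a nitrogen on an aromatic ring, so the second arm becomes an amide instead of a sulfonamide.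

Among the measured compounds shown here, no measured pair differs in one place, so the size of this step cannot be read from the data. The expectation is that the step from compound 1 to compound 4 in this assay is an at least 2.0-fold lower number from compound 1 to compound 4 (0.30 log units; that floor lies within the scatter), in the direction of stronger inhibition, though a result at the limit remains likely. For compound 4 the estimated value is 50000 nM, within a range from 5000 nM to 200000 nM.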

Compound 4, half-maximal inhibitory concentration: > 100000 nM
Compound 4: only a limit was reported (the forecaster's own chance of this, stated with the estimate: 60%); middle value at least 2.0-fold (0.30 log units) away from the limit.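

Compound 4, like compound 1, gives only a limit in this assay, so the step between them cannot be read, in size or in direction: the limit of > 100000 nM in this assay, at which 4 of the 4 values shown sit. The compounds shown leave open whether any pair of arms on this shared core can give a real number in this assay.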